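A few compounds are considered here, and "the series" means these few. Any claim that something is new, unique, unknown or untested is made for them only; others in the source may bear on it.

In a functional assay on MCF7 cells (Homo sapiens) for inhibition, read by MTT assay, with a stated time of 72 h (on this read-out higher numbers stand for weaker inhibition of growth and lower numbers for stronger inhibition of growth), compound 1 (`CCOC(=O)/C=C/C1=CC[C@H]2C(C)(C)CCC[C@]2(C)[C@H]1C=O`) gives 30000 nM and sits level with the other two measured members of the series. Compound 2 (`CCOC(=O)/C(C)=C/C1=CC[C@H]2C(C)(C)CCC[C@]2(C)[C@H]1C=O`) gives 27000 nM and compound 3 (`CC1(C)CCC[C@]2(C)[C@@H](C=O)C(/C=C/C(=O)OCc3ccccc3)=CC[C@@H]12`) gives 27000 nM on the same read-out, so all three numbers lie within the scatter of one another and compound 1 holds no meaningful rank among them. The next member is compound 4 (`CC(=O)/C=C/C1=CC[C@H]2C(C)(C)CCC[C@]2(C)[C@H]1C=O`), still unmeasured. Its difference from compound 1 is methyl in place of ethoxy on a carbonyl carbon and amounts to methyl in place of ethoxy on a carbonyl carbon, that is, ethoxycarbonyl to acetyl. Among the measured compounds shown here, the one measured step that alters this group is a 1.1-fold lower number from compound 1 to compound 3 (0.05 log units; within the scatter) and it stays within the scatter. For the measured compounds named here, that step keeps the oxygen on the carbonyl carbon, so it does not test the loss of ethoxy, and no measured compound does. Going by the values given here, with only that small step as a guide, the expected change is modest and not expected to pass the scatter, an estimated 1.5-fold lower number from compound 1 to compound 4 (0.18 log units; within the scatter) on present data. For compound 4 the estimated value is 20000 nM with an expected range from 9000 nM to 40000 nM in this assay until the measurement is in.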

Compound 4, concentration for 50% growth inhibition: 20000 nM
For compound 4 middle estimate and measured number coincide at the digits printed; low and high end bracket the measured number.
By their numbers in this assay, from the lowest: compounds 4, 2, 3 and 1 (each within the scatter of the next).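

In this assay the group on the carbonyl carbon can lose its oxygen without a step beyond the scatter (a 1.5-fold lower number from compound 1 to compound 4 (0.18 log units; within the scatter); a 1.4-fold lower number from compound 3 to compound 4 (0.13 log units; within the scatter)). Compound 3 only exchanged what sits on that oxygen, whereas ethoxycarbonyl to acetyl removes the oxygen itself, so among compound 1, compound 3 and compound 4 neither that oxygen nor the ethoxy or benzyloxy group is required for the read-out to stay at this level. No evidence is available that bears on this result.

All four numbers in the series lie within the scatter of their neighbours, so this position has not yet shown any change that separates one compound from another, and a flat response across methyl, ethoxy and benzyloxy says little about groups of another kind. From the compounds shown here alone, whether an amine on the carbonyl carbon, giving an amide, a free carboxylic acid, or a longer chain in place of methyl would move the number beyond the scatter remains open, as does the contribution of the aldehyde carried by the shared core.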